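The source may report more compounds than this note shows. Statements on the series, on what has been measured and on what is new or still open speak of the compounds shown alone.

Compound 1 `CC(=O)N1N=C(Nc2nc3ccccc3s2)CC1OC1=CC=C1`: 382 umol/kg
Compound 2 `CC(=O)N1N=C(Nc2nc3ccc(Cl)cc3s2)CC1OC1=CC=C1`: 212 umol/kg
Compound 3 `O=C(/C=C/OC1=CC=C1)Nc1nc2ccc(Cl)cc2s1`: 544 umol/kg

In a functional assay on the whole organism (Hindlimb, strain albino) with Mus musculus as the target, in the maximal electroshock model, with a stated time of 0.5 h (on this read-out higher numbers stand for an effect only at larger amounts of compound and lower numbers for an effect already at smaller amounts), compound 1 stands second highest of the three numbers; compound 3 is nearest and compound 2 furthest, both within the scatter. Among the compounds with values here, the only step between measured compounds, a 1.8-fold lower number from compound 1 to compound 2 (0.26 log units; within the scatter), concerns the aromatic carbon of the shared core and not the saturated ring carbon. Compound 4 `CC(=O)N1N=C(Nc2nc3ccccc3s2)CC1c1ccccc1` differs from compound 1 by a group of 6 heavy atoms (6 carbon; one six-membered aromatic ring of carbon only) in place of a group of 5 heavy atoms (4 carbon, 1 oxygen; one four-membered non-aromatic ring of carbon only), on a saturated ring carbon. Within the data shown here, no measured step touches this position, so the measured data give no direction for the change, and no step beyond the scatter is expected. Compound 4 is therefore estimated at 400 umol/kg in this assay, within 150 umol/kg to 1100 umol/kg, and the expected 1.0-fold higher number from compound 1 to compound 4 (0.02 log units; within the scatter) is small.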

Compound 4, dose for half-maximal effect: 315 umol/kg
Compound 4: middle estimate off by 1.3-fold (0.10 log units), on the high side, and the stated range covers the measured number.
By their numbers in this assay, from the lowest: compounds 2, 4, 1 and 3 (each within the scatter of the next, the first and the last beyond it).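

In this assay, phenyl on the saturated ring carbon replaces the group with the four-membered ring and its oxygen, and a 1.2-fold lower number from compound 1 to compound 4 (0.08 log units; within the scatter) shows that this exchange at this position gives no step beyond the scatter. The earlier compounds shown here offered no step at this position, only one on an aromatic carbon. Nothing measured here bears on why the two groups read alike. Still open, as far as these compounds go, is whether an amine, a carboxylic acid or a longer chain on this carbon would stay within the scatter, and whether chloro on the aromatic carbon would give the same reading alongside phenyl.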